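Swapping a sulfoximine for a dipropylsulfamoyl group

A few compounds are considered here, and "the series" means these few. Any claim that something is new, unique, unknown or untested is made for them only; others in the source may bear on it.

This set of three measured compounds was tested in a functional assay on MIA PaCa-2 cells (Homo sapiens) for inhibition, read by MTT assay, with a stated time of 3 days; a higher number here means a weaker inhibitor, a lower number a stronger inhibitor. Compound 1, `CCOC(=O)[C@H]1CCN(S(=O)(=O)c2ccc(S(=O)(=O)N(CC)CC)cc2)C1`, reached only the assay limit, giving > 10000 nM, so no number is known for it (the limit of > 10000 nM in this assay, at which 1 of the 3 values shown sits). Compound 3, `CCOC(=O)C12CC(CN(S(=O)(=O)c3ccc(S(=O)(=O)N(CC)CC)cc3)C1)C2`, gives 400 nM. Compound 2, `CCOC(=O)[C@@H]1CCCN(S(=O)(=O)c2ccc(S(=N)(=O)N(CC)CC)cc2)C1`, gives 900 nM, the higher of the two numbers; its gap to compound 3 lies beyond the usual scatter of repeated measurements.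

Compound 4, `CCCN(CCC)S(=O)(=O)c1ccc(S(=O)(=O)N2CCC[C@@H](C(=O)OCC)C2)cc1`, has not yet been measured. It differs from compound 2 in one place: a group of 10 heavy atoms (6 carbon, 1 nitrogen, 2 oxygen, 1 sulfur; no ring) in place of a group of 8 heavy atoms (4 carbon, 2 nitrogen, 1 oxygen, 1 sulfur; no ring), on an aromatic carbon. The group that leaves carries a hydrogen-bond donor; the group that enters carries none. Going by the values given here, no measured pair shows this kind of change, so the size of the step is uncertain. The step from compound 2 to compound 4 is expected to be a 1.7-fold higher number from compound 2 to compound 4 (0.22 log units; within the scatter), a modest weakening. Compound 4 is therefore estimated at 1500 nM, with a range from 300 nM to 8000 nM.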

Compound 4, half-maximal inhibitory concentration: 600 nM
The estimate for compound 4 lay 2.5-fold (0.40 log units) above the measured number, and the stated range covers the measured number.
By their numbers in this assay, from the lowest: compounds 3, 4 and 2 (each within the scatter of the next, the first and the last beyond it). At a limit, above all of these: compound 1.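

Going by these compounds alone, the first step that can be read in this set is a 1.5-fold lower number from compound 2 to compound 4 (0.18 log units; within the scatter), on an aromatic carbon, para to a large group. The dipropylsulfamoyl group that enters has no hydrogen-bond donor and the group that leaves has one, yet the two compounds remain within the scatter of each other, so in this pair neither that donor nor the smaller group is needed for a value in this range. Nothing measured here gives a cause for this result.

This single pair cannot show how far the position tolerates other groups, such as a shorter dimethylsulfamoyl group, a longer dibutylsulfamoyl group or a plain amine on that carbon. Also open, going by these compounds, is whether the result would hold if a carboxylic acid replaced the ethyl ester.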